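Aryl-piperazine urea series: binding data

The source may report more compounds than this note shows. Statements on the series, on what has been measured and on what is new or still open speak of the compounds shown alone.

Three compounds of the series carry measurements. Compound 1 `COCC1=C(C(=O)OC)C(c2cc(F)c(F)cc2F)N(C(=O)NCCCN2CCN(c3ccccc3C(N)=O)CC2)C(=O)N1` gives, in an assay on liver for binding affinity to Alpha-1A adrenergic receptor (Homo sapiens), using microsomes (a higher number here means a weaker inhibitor, a lower number a stronger inhibitor), a value of 0.1 nM. Compound 2 `COC(=O)C1=C(C)NC(=O)N(C(=O)NCCCN2CCN(c3ccc(Cl)cc3)CC2)C1c1ccc(F)c(F)c1` gives in this assay 0.8 nM, and compound 3 `CC(=O)C1=C(C)NC(=O)N(C(=O)NCCCN2CCN(c3ccccc3C(N)=O)CC2)C1c1ccc(F)c(F)c1` gives 0.7 nM. Among these three numbers compound 2 stands highest; its nearest neighbour is compound 3, whose number lies within the scatter, while compound 1 lies beyond the scatter on the lower side. Among the measured compounds shown here, no pair of the measured compounds differs in only one place, so no single step is known from them.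

Compound 4 `COC(=O)C1=C(C)NC(=O)N(C(=O)NCCCN2CCN(c3ccccc3OC)CC2)C1c1ccc(F)c(F)c1` is not yet measured. It differs from compound 2 in one place: 2-methoxyphenyl in place of 4-chlorophenyl on an amine nitrogen in a ring.

For the measured compounds named here, since no measured step of this kind exists here, the expectation rests on the range already seen. Compound 1 gives 0.1 nM, so numbers well below that of compound 2 occur within the series. For compound 4 a step of a 2.0-fold lower number from compound 2 to compound 4 (0.30 log units; within the scatter) is expected, in the direction of a lower number, of a size around the edge of the scatter. The estimate for compound 4 in this assay is 0.4 nM, with a range from 0.1 nM to 1.5 nM.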

Compound 4, inhibition constant: 0.1 nM
Beside the measured number, compound 4's estimate is 4.0-fold (0.60 log units) above it; low and high end bracket the measured number.
By their numbers in this assay, from the lowest: compounds 1 and 4 (each within the scatter of the next); then compounds 3 and 2 (each within the scatter of the next).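

In this assay, among the compounds shown here, 2-methoxyphenyl in place of 4-chlorophenyl on an amine nitrogen in a ring gives an 8.0-fold lower number from compound 2 to compound 4 (0.90 log units; beyond the scatter), the first step that can be read at a single place. The earlier compounds shown here each differed in more than one place, so they could not show that this aryl group alone, with the rest of the compound held fixed, moves the number beyond the scatter; the swap also goes from a group with no hydrogen-bond acceptor to one with one, and it changes both the substituent and where it sits on the aromatic ring. Nothing on hand accounts for the size or direction of this step.

This single step cannot separate the identity of the substituent from its place on the ring, and a pair such as 2-chlorophenyl and 4-methoxyphenyl, or unsubstituted phenyl as a common reference, would pull the two apart. It also leaves open whether the same swap gives a step of similar size on a compound with another group on the shared core, such as an ethyl ester.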